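This account rests on a few compounds, and the source may have more. Where it says the series, first, only, none or still open, it means among the compounds named here.

Measured compounds in a functional assay on cells for agonist activity at Free fatty acid receptor 1 (Mus musculus), read by FLIPR and calcium flux, with a stated time of 5 min; on this read-out lower numbers stand for smaller maximal responses and higher numbers for larger maximal responses:

compound 1 `Cc1nn(-c2ccccn2)c2cc(-c3ccc(CCC(=O)O)cc3)ccc12`: 95%
compound 2 `Cc1nn(-c2ccccn2)c2cc(-c3ccc(CCC(=O)O)cc3F)ccc12`: 105%
compound 3 `COc1nn(-c2ccccn2)c2cc(-c3ccc([C@H]4C[C@@H]4C(=O)O)cc3)cc(F)c12`: 19%

Compound 2 and compound 1 share a core and differ in one place, (hydrogen in place of fluoro on an aromatic carbon). In this assay this gave a number 10 percentage points lower from compound 2 to compound 1 (within the scatter). Compound 3 stands apart from both, with a different core; how its core differs from that of compound 2 is not broken down here. Its value in this assay is the lowest of the three.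

Compound 4 `COc1nn(-c2ccccn2)c2cc(-c3ccc([C@H]4C[C@@H]4C(=O)O)cc3)ccc12` is not yet measured. It differs from compound 3 by hydrogen in place of fluoro on an aromatic carbon. This is the same kind of change as from compound 2 to compound 1, but the surroundings differ: there the place was ortho to a large group and meta to a 2-carboxyethyl group, whereas here it is part of a fused or bridged system of two rings, ortho to a fused ring, meta to a fused ring and meta to a large group. Resting on the earlier step of a number 10 percentage points lower from compound 2 to compound 1 (within the scatter), the expected step is a number 9 percentage points higher from compound 3 to compound 4 (within the scatter). Compound 4 is estimated to give 28% in this assay, with a range from 12% to 55%.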

Compound 4, largest response reached (reported as efficacy), in percent of the reference or control that the assay uses in the Free fatty acid receptor 1 assay: 1%
Compound 4: the middle estimate sits 27 percentage points above what was measured; the whole stated range lies above it.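

In the Free fatty acid receptor 1 assay the change from fluoro to hydrogen on an aromatic carbon gave a number 18 percentage points lower from compound 3 to compound 4 (beyond the scatter), and the same change on the two cores does not differ in size by more than the scatter allows: the same change on two cores in the Free fatty acid receptor 1 assay, a number 10 percentage points lower (within the scatter) from compound 2 to compound 1 and a number 18 percentage points lower (beyond the scatter) from compound 3 to compound 4, 8 percentage points apart, within the scatter of two such steps In a physicochemical assay for lipophilicity, using the shake flask method, measured as octanol-water partition, with a stated time of 30 min, at pH 7.4 (on this read-out lower numbers stand for lower lipophilicity and higher numbers for higher lipophilicity), compound 3 gives 3.8 and compound 4 gives 3.8, the same printed number. These two pairs show that the change carried over between these two cores, but they do not show that it would carry over to a third core, and the step on the first core alone lies within the scatter.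

The compounds shown leave open how chloro or a nitrile on this aromatic carbon would read in the Free fatty acid receptor 1 assay. They also leave open how a primary amide in place of the carboxylic acid would read on either core.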